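Turning One Ring Stereocentre While Keeping Everything Else

The source may hold more compounds than are shown below. What is called first, only, known or untested is meant among the compounds shown, and "the series" means these compounds.

Of the compounds shown here, three built on one shared core have been tested in an assay on Sf9 cells for inhibition of histone deacetylase 11 (Homo sapiens), read by fluorescence, tested at 0.5 uM; a lower number here means less inhibition, a higher number more inhibition at the concentration tested (going by the name of the read-out). Compound 1, `O=C(NO)c1ccc(-c2cn([C@@H]3C[C@H](C(=O)O)N(Cc4ccccc4)C3)nn2)cc1`, is reported in this assay only as a limit, < 10%. Compound 2, `O=C(NO)c1cccc(-c2cn([C@H]3C[C@@H](C(=O)O)N(Cc4ccccc4)C3)nn2)c1`, gives 14% in this assay. Compound 3, `O=C(NO)c1cccc(-c2cn([C@@H]3C[C@@H](C(=O)O)N(Cc4ccccc4)C3)nn2)c1`, is likewise reported in this assay only as a limit, < 10%. Among the compounds with values here, the single step measured between close neighbours, a number at least 4 percentage points lower from compound 2 to compound 3 (that floor lies within the scatter), stays within the scatter; what can be said of it rests on the limit of < 10% in this assay, at which 2 of the 3 values shown sit, and on (the fact that compounds 2 and 3 differ only in the configuration as drawn).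

Compound 4, `O=C(NO)c1cccc(-c2cn([C@@H]3C[C@H](C(=O)O)N(Cc4ccccc4)C3)nn2)c1`, differs from compound 3 only in this way: the two compounds have the same atoms and bonds and differ only in configuration as drawn: 1 of 2 stereo elements differ; a stereocentre at a saturated ring carbon is drawn S in compound 3 and R in compound 4. Within the data shown here, the one measured step that bears on such a change, a number at least 4 percentage points lower from compound 2 to compound 3 (that floor lies within the scatter), was too small to count, so no movement beyond the scatter is expected here, and compound 4 may well again be reported only as a limit. The step from compound 3 to compound 4 is therefore estimated as a number no lower from compound 3 to compound 4 (the limit leaves the size open). Compound 4 is expected to give about 10% in this assay, somewhere between 0% and 22%.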

Compound 4, a percentage reported as inhibition, at one concentration (the size of the read-out at that concentration, not a potency): < 10%
Compound 4: only a limit was reported; the forecaster's own chance of this, stated with the estimate: 55%; the middle value sits exactly at the limit.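

Compound 4 is the mirror image of compound 2, so this result tests both stereocentres inverted together rather than one alone, and in this assay it gives a number at least 4 percentage points lower from compound 2 to compound 4 (that floor lies within the scatter): the fact that compounds 2 and 4 differ only in the configuration as drawn. Even this complete inversion therefore shows no change beyond the scatter, and the limit leaves the true size of the step open. The steps joining compound 4 to compound 3 and to compound 1 cannot be read, since both compounds in each pair sit at a limit.

On these data alone, it remains open whether replacing the carboxylic acid on the shared core with a primary amide would lift the reading clear of the limit. As far as these compounds go, it also remains open whether the configuration at these two ring carbons would matter once that reading rose.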